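Varying the amide substituent on a stilbene-cinnamamide scaffold

The source may report more compounds than this note shows. Statements on the series, on what has been measured and on what is new or still open speak of the compounds shown alone.

Compound 1 `COc1ccc(/C=C/c2cc(OC)cc(OC)c2/C=C/C(=O)NC2CC2)cc1` is tested in a functional assay on A549 cells (Homo sapiens) for inhibition, read by MTT assay, with a stated time of 48 h (on this read-out lower numbers stand for stronger inhibition and higher numbers for weaker inhibition), where compound 1 gives 8810 nM. Two close relatives differ from it only in the group carried on the amide nitrogen. Compound 2 `CCCCN(CCCC)C(=O)/C=C/c1c(/C=C/c2ccc(OC)cc2)cc(OC)cc1OC` gives 6160 nM, and compound 3 `COc1ccc(/C=C/c2cc(OC)cc(OC)c2/C=C/C(=O)N2CCCC2)cc1` gives 6350 nM. The steps of a 1.4-fold lower number from compound 1 to compound 2 (0.16 log units; within the scatter) and a 1.4-fold lower number from compound 1 to compound 3 (0.14 log units; within the scatter) both lie within the scatter, as does a 1.0-fold higher number from compound 2 to compound 3 (0.01 log units; within the scatter), so the three compounds stand together and compound 1 is not set apart from them by these numbers.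

Compound 4 `CCCCCCNC(=O)/C=C/c1c(/C=C/c2ccc(OC)cc2)cc(OC)cc1OC` has not yet been measured. It differs from compound 1 in one place: hexyl in place of cyclopropyl on an amide-type nitrogen. Every change at this amide nitrogen seen so far, whether dibutylamino or pyrrolidin-1-yl in place of cyclopropylamino, left this assay within the scatter. On that basis the expected step for compound 4 is a 1.3-fold lower number from compound 1 to compound 4 (0.10 log units; within the scatter), none beyond the scatter. Compound 4 is therefore estimated at 7000 nM, with a range from 3000 nM to 16000 nM.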

Compound 4, half-maximal inhibitory concentration: 6230 nM
Compound 4: middle estimate off by 1.1-fold (0.05 log units), on the high side; low and high end bracket the measured number.
By their numbers in this assay, from the lowest: compounds 2, 4, 3 and 1 (each within the scatter of the next).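

Taking out the three-membered ring and putting in an open hexyl chain, with more carbon on the same amide-type nitrogen, still stays within the scatter in this assay (a 1.4-fold lower number from compound 1 to compound 4 (0.15 log units; within the scatter)). The earlier compounds shown here showed only a ring of another size and a pair of butyl chains, and the single hexyl chain cannot be told apart from either: the pyrrolidin-1-yl group of compound 3 (a 1.0-fold lower number from compound 3 to compound 4 (0.01 log units; within the scatter)) or the dibutylamino group of compound 2 (a 1.0-fold higher number from compound 2 to compound 4 (0.00 log units; within the scatter)). Nothing measured here accounts for how closely these four compounds stand together.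
Every group shown on this nitrogen is built from carbon alone, so a chain ending in an amine or a carboxylic acid remains open. So does a benzyl group, or a plain amide with only hydrogen on the nitrogen.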